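From compound 3 to compound 4: a carbamoylamino exchange

The compounds below may be only part of what the source reports. "The series", "measured", "known", "first", "only" and "open" are said of these compounds alone.

In a functional assay on NCI-H460 cells (Homo sapiens) for inhibition, read by MTT assay, with a stated time of 72 h (on this read-out higher numbers stand for weaker inhibition and lower numbers for stronger inhibition), compound 1 `COc1cc(NC(C)CCCNC(=O)NNC(=O)Nc2ccc(F)cc2)c2ncccc2c1` gives > 100000 nM as a limit of the assay, not a number. Compound 2 `COc1cc(NC(C)CCCNC(=O)Nc2cccc(O)c2)c2ncccc2c1` reads 25000 nM and compound 3 `COc1cc(NC(C)CCCNC(=O)Nc2cccc(C(F)(F)F)c2)c2ncccc2c1` reads 21000 nM in the same test. Among the compounds with values here, compound 3 therefore stands level with the one other true number, and the step of a 1.2-fold lower number from compound 2 to compound 3 (0.08 log units; within the scatter) lies inside the scatter.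

The next structure, compound 4 `COc1cc(NC(C)CCCNC(=O)NNC(=O)Nc2ccc(O)cc2)c2ncccc2c1`, is still unmeasured. Relative to compound 3 it carries ((4-hydroxyphenyl)carbamoyl)amino in place of 3-(trifluoromethyl)phenyl on an amide-type nitrogen.

The nearest evidence is the same kind of exchange run the other way. Compound 1 carries ((4-fluorophenyl)carbamoyl)amino on that nitrogen, and the step of an at least 4.7-fold lower number from compound 1 to compound 3 (0.67 log units; beyond the scatter) is beyond the scatter, as is the step of an at least 4.0-fold lower number from compound 1 to compound 2 (0.60 log units; beyond the scatter) on the same nitrogen. Both steps start from a limit, so their true size is open. Compound 4 is thus expected to move back toward compound 1, though fluoro and hydroxy on this group have not been compared directly. The expected step, toward a higher number, is a 2.9-fold higher number from compound 3 to compound 4 (0.46 log units; beyond the scatter) in size, and a reading of only a limit is quite possible. In this assay compound 4 is estimated at 60000 nM with a range of 20000 nM to 150000 nM as expected bounds.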

Compound 4, half-maximal inhibitory concentration: > 100000 nM
Compound 4 ended at the assay's limit; the forecaster's own chance of this, stated with the estimate: 45%; at least 1.6-fold (0.22 log units) between middle value and limit.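

In this assay, the exchange to ((4-hydroxyphenyl)carbamoyl)amino on the amide-type nitrogen gives an at least 4.7-fold higher number from compound 3 to compound 4 (0.67 log units; beyond the scatter) and an at least 4.0-fold higher number from compound 2 to compound 4 (0.60 log units; beyond the scatter). The drop seen earlier with the ((4-fluorophenyl)carbamoyl)amino group of compound 1 is therefore not tied to fluoro alone: compound 1 and compound 4, with fluoro and hydroxy on this group, both end at a limit of the assay and not at a number, while the 3-hydroxyphenyl of compound 2 and the 3-(trifluoromethyl)phenyl of compound 3 both give true numbers. The step from fluoro to hydroxy, however, cannot be read, and the two limits say nothing on the order of compound 1 and compound 4: the limit of > 100000 nM in this assay, at which 2 of the 4 values shown sit.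

Going by these compounds, the true size of the steps to compound 4 stays open, and the four compounds do not separate the effect of the carbamoylamino group itself from that of the substituent on its ring. Also open, on these data alone, is how this group would read with a methoxy or an amine on that ring, and how a simple methyl on the amide-type nitrogen would read in its place.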